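Swapping the aryl group on the isoxazole: toward a fluorophenyl analogue

The compounds below may be only part of what the source reports. "The series", "measured", "known", "first", "only" and "open" are said of these compounds alone.

Compounds measured so far:
- compound 1, `CCOC(=O)C1=Cc2ccccc2OC1(OCc1cc(-c2ccc(OC)cc2)no1)C(F)(F)F`: > 150000 nM
- compound 2, `CCOC(=O)C1=Cc2ccccc2OC1(OCc1cc(-c2ccc(Br)cc2)no1)C(F)(F)F`: 71700 nM
- compound 3, `CCOC(=O)C1=Cc2ccccc2OC1(OCc1cc(-c2cccc(C(F)(F)F)c2)no1)C(F)(F)F`: 57300 nM

In a functional assay on DU-145 cells (Homo sapiens) for inhibition, read by MTT assay, with a stated time of 24 h (on this read-out higher numbers stand for weaker inhibition and lower numbers for stronger inhibition), compound 1 reaches only a limit of the assay, > 150000 nM (the limit of > 150000 nM in this assay, at which 1 of the 3 values shown sits). Compound 2 gives 71700 nM and compound 3 gives 57300 nM in this assay. Compound 3 holds the lowest of the two numbers that are not limits, yet the step of a 1.3-fold lower number from compound 2 to compound 3 (0.10 log units; within the scatter) lies within the scatter, so compounds 2 and 3 cannot be ranked against each other. The steps of an at least 2.0-fold lower number from compound 1 to compound 2 (0.32 log units; beyond the scatter) and an at least 2.6-fold lower number from compound 1 to compound 3 (0.41 log units; beyond the scatter) are the two that go beyond the scatter.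

Compound 4, `CCOC(=O)C1=Cc2ccccc2OC1(OCc1cc(-c2ccc(F)cc2)no1)C(F)(F)F`, has not yet been measured. It differs from compound 3 by 4-fluorophenyl in place of 3-(trifluoromethyl)phenyl on an aromatic carbon. Among the compounds with values here, the closest precedent is compound 2, whose bromo group sits on the same ring carbon as the fluoro of compound 4, and whose step from compound 1 is an at least 2.0-fold lower number from compound 1 to compound 2 (0.32 log units; beyond the scatter). Compound 4 is therefore expected to land between compounds 2 and 1, with a step of a 1.6-fold higher number from compound 3 to compound 4 (0.20 log units; within the scatter) that may be small. Compound 4 is estimated at 90000 nM in this assay, within 40000 nM to 200000 nM.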

Compound 4, half-maximal inhibitory concentration: 53500 nM
For compound 4 the middle estimate is 1.7-fold (0.23 log units) above the measured one; measured number inside the range.
By their numbers in this assay, from the lowest: compounds 4, 3 and 2 (each within the scatter of the next). At a limit, above all of these: compound 1.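

Exchanging 3-(trifluoromethyl)phenyl for 4-fluorophenyl on the aromatic carbon next to the ring nitrogen changes nothing that can be read in this assay, with a 1.1-fold lower number from compound 3 to compound 4 (0.03 log units; within the scatter). Fluoro in place of bromo likewise gives a 1.3-fold lower number from compound 2 to compound 4 (0.13 log units; within the scatter), so compounds 2, 3 and 4 cannot be ranked, and three different aryl groups at this position read alike. Only compound 1, with its 4-methoxyphenyl group, goes against this, with an at least 2.8-fold lower number from compound 1 to compound 4 (0.44 log units; beyond the scatter), and that step rests on a limit of the assay: the limit of > 150000 nM in this assay, at which 1 of the 4 values shown sits.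

The compounds shown leave open whether an amine or a carboxylic acid on the aryl ring would move the number beyond the scatter of compounds 2, 3 and 4. Also open, as far as these compounds go, is how an unsubstituted phenyl or a longer alkoxy chain would read at this position.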